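The source may report more compounds than this note shows. Statements on the series, on what has been measured and on what is new or still open speak of the compounds shown alone.

Compound 1 `CCN(Cc1cccs1)C(=O)COc1ccc(C)cc1` gives 8 nM in an assay on HEK293 cells for agonist activity at transient receptor potential cation channel subfamily M member 8 (Homo sapiens), read by fluorescence and calcium flux, with a stated time of 15 min; a lower number here means that less compound is needed, a higher number that more compound is needed for the effect. Compound 2 `Cc1ccc(OCC(=O)N(Cc2cccs2)c2ccn(C)n2)cc1` gives 855 nM in this assay, and compound 3 `Cc1ccc(OCC(=O)N(Cc2cccs2)C2COC2)cc1` gives 23000 nM, the highest of the three numbers; the step of a 27-fold higher number from compound 2 to compound 3 (1.43 log units; beyond the scatter) and the step of a 2900-fold higher number from compound 1 to compound 3 (3.46 log units; beyond the scatter) are both large. Compound 4 `COCCN(Cc1cccs1)C(=O)COc1ccc(C)cc1` is not yet measured. The change from compound 3: 2-methoxyethyl in place of oxetan-3-yl on an amide-type nitrogen. The step of a 2900-fold higher number from compound 1 to compound 3 (3.46 log units; beyond the scatter) bears most directly on this change: compound 4, like compound 1, carries a chain on the amide-type nitrogen rather than the ring of compound 3, so a large fall in the number is expected. For compound 4 the expected step is a 770-fold lower number from compound 3 to compound 4 (2.88 log units; beyond the scatter). Compound 4 is estimated at 30 nM, within 6 nM to 150 nM.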

Compound 4, half-maximal effective concentration: 400 nM
For compound 4 the middle estimate is 13-fold (1.12 log units) below the measured one; measured number outside the range, above it.
By their numbers in this assay, from the lowest: compound 1; then compound 4; then compound 2; then compound 3.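

2-Methoxyethyl and oxetan-3-yl have the same counts of heavy atoms and hydrogen-bond acceptors, yet the change gives a 58-fold lower number from compound 3 to compound 4 (1.76 log units; beyond the scatter) in this assay, so these counts alone do not set the number at this position. A chain alone does not restore the level of compound 1: adding methoxy gives a 50-fold higher number from compound 1 to compound 4 (1.70 log units; beyond the scatter), and the comparison with the pyrazolyl group shows only a 2.1-fold lower number from compound 2 to compound 4 (0.33 log units; beyond the scatter). No supporting data bear on the reason for these steps. Open, as far as these compounds go, is how a plain propyl chain, or a chain ending in an amine, would compare with ethyl and 2-methoxyethyl.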